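The source may report more compounds than this note shows. Statements on the series, on what has been measured and on what is new or still open speak of the compounds shown alone.

Compound 1 `CC1(C)Oc2ccc(C#N)cc2[C@H](Nc2ccccc2)[C@H]1O` carries hydrogen on the nitrogen on the aromatic ring. In a functional assay (aorta) with Rattus norvegicus as the target (on this read-out lower numbers stand for stronger inhibition and higher numbers for weaker inhibition), compound 1 gives 1200 nM. Compound 2 `CC(=O)NCCN(c1ccccc1)[C@H]1c2cc(C#N)ccc2OC(C)(C)[C@@H]1O` carries 2-acetamidoethyl on that nitrogen instead. In this assay compound 2 gives only a limit, > 30000 nM. The step is an at least 25-fold higher number from compound 1 to compound 2 (1.39 log units; beyond the scatter), with compound 2 sitting at the limit of > 30000 nM in this assay, at which 1 of the 2 values shown sits. Compound 3 `Cc1cc(CN(c2ccccc2)[C@H]2c3cc(C#N)ccc3OC(C)(C)[C@@H]2O)on1` brings (3-methyl-1,2-oxazol-5-yl in place of acetamidomethyl on a saturated chain carbon bound to a nitrogen on an aromatic ring). Among the measured compounds shown here, the only measured step that bears on this change is the one that attached a group to the nitrogen, an at least 25-fold higher number from compound 1 to compound 2 (1.39 log units; beyond the scatter), and compound 3 keeps a group of similar size there. For the measured compounds named here, no measured pair shows one such group exchanged for another, so the direction of any shift is open. Compound 3 is therefore expected to stay near the weak end, with a fair chance of being reported again as a limit; the estimate for compound 3 is 20000 nM with a range from 5000 nM to 60000 nM. The expected step is an at least 1.5-fold lower number from compound 2 to compound 3 (0.17 log units; that floor lies within the scatter).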

Compound 3, half-maximal inhibitory concentration: > 30000 nM
Compound 3: a limit, no number (the forecaster's own chance of this, stated with the estimate: 45%); middle value at least 1.5-fold (0.17 log units) away from the limit.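

In this assay, a second and quite different group on the nitrogen on the aromatic ring also leaves the compound far weaker, with an at least 25-fold higher number from compound 1 to compound 3 (1.39 log units; beyond the scatter). The loss is therefore not tied to acetamidomethyl: it persists when that group gives way to 3-methyl-1,2-oxazol-5-yl, which has an aromatic ring and no hydrogen-bond donor, and neither compound 2 nor compound 3 goes against this pattern. The step from compound 2 to compound 3 cannot be read, because both compounds sit at the same limit: the limit of > 30000 nM in this assay, at which 2 of the 3 values shown sit.

The compounds shown leave open whether a small group such as methyl on this nitrogen would keep a measurable value. They also leave open whether an amine or a carboxylic acid at the end of the chain would fare any differently.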